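Cyano for difluoromethyl on the compound 1 aromatic group

The source may report more compounds than this note shows. Statements on the series, on what has been measured and on what is new or still open speak of the compounds shown alone.

In an ADME assay on microsomes from liver (Homo sapiens) for metabolic stability (on this read-out lower numbers stand for a shorter-lived compound and higher numbers for a longer-lived compound), compound 1 `NS(=O)(=O)CC(=O)NCCSc1nonc1/C(=N/O)Nc1ccc(F)c(C(F)F)c1` gives 2.77 h. Compound 3 `N#CCC(=O)NCCSc1nonc1/C(=N/O)Nc1ccc(F)c(C(F)F)c1` gives 2.77 h, level with compound 1 at the digits shown. Compound 2 `CC1(C(=O)NCCSc2nonc2/C(=N/O)Nc2ccc(F)c(C(F)F)c2)CCN1` gives 1.97 h, within the scatter of both.

Compound 4 `N#Cc1cc(N/C(=N\O)c2nonc2SCCNC(=O)CS(N)(=O)=O)ccc1F` keeps the sulfamoyl side chain of compound 1 and differs by cyano in place of difluoromethyl on an aromatic carbon, ortho to a fluoro group, which turns 3-(difluoromethyl)-4-fluorophenyl into 3-cyano-4-fluorophenyl.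

Two measured steps start from compound 1: a 1.4-fold lower number from compound 1 to compound 2 (0.15 log units; within the scatter) and no change at the digits printed from compound 1 to compound 3 (within the scatter). Both change the group on the carbonyl carbon and leave the aromatic group untouched, so they bear on this change only indirectly. They show a tolerant side chain, but no measurement tests the aromatic swap itself.

The expected step is a 1.1-fold lower number from compound 1 to compound 4 (0.04 log units; within the scatter), with nothing expected beyond the scatter and the direction left open. For compound 4 the estimated half-life is 2.5 h, with an expected range of 1.3 h to 4.5 h.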

Compound 4, half-life: > 3 h
Compound 4 gave a limit, no number; the forecaster's own chance of this, stated with the estimate: 5%; at least 1.2-fold (0.07 log units) between middle value and limit.
By their numbers in this assay, from the lowest: compounds 2, 1 and 3 (each within the scatter of the next). At a limit, above all of these: compound 4.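

In this assay compound 4 is reported only as a limit, > 3 h, not as a number. Read as a step, cyano in place of difluoromethyl gives an at least 1.0-fold higher number from compound 1 to compound 4 (0.03 log units; that floor lies within the scatter), so this first change on the aromatic group, where the earlier compounds varied only the group on the carbonyl carbon, shows no loss of half-life on going to 3-cyano-4-fluorophenyl. The size of any gain cannot be read from this result: the limit of > 3 h in this assay, at which 1 of the 4 values shown sits.

The compounds shown leave open whether cyano brings a gain beyond the scatter, and whether the swap reads the same with the side chains of compound 2 and compound 3. They also leave open how trifluoromethyl, an amine or a carboxylic acid at this aromatic carbon would read in this assay.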